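The compounds below may be only part of what the source reports. "The series", "measured", "known", "first", "only" and "open" are said of these compounds alone.

Measured so far in an assay for inhibition of beta-glucuronidase (Bos taurus), read by spectrophotometry, with a stated time of 30 min; on this read-out lower numbers stand for stronger inhibition and higher numbers for weaker inhibition:
compound 1, `Oc1ccc(C(c2c[nH]c3ccc(Br)cc23)c2c[nH]c3ccc(Br)cc23)c(O)c1`, gives 1620 nM;
compound 2, `Cc1ccccc1C(c1c[nH]c2ccc(Br)cc12)c1c[nH]c2ccc(Br)cc12`, gives 20900 nM.

Compound 1 stands lowest of the two numbers shown, and the only other number, that of compound 2, lies well above it. Among the measured compounds shown here, the single measured step that bears on the present question is a 13-fold higher number from compound 1 to compound 2 (1.11 log units; beyond the scatter), in which the whole 2,4-dihydroxyphenyl on the saturated chain carbon bound to two aromatic carbons is exchanged for 2-methylphenyl. Compound 3, `Oc1ccc(C(c2c[nH]c3ccc(Br)cc23)c2c[nH]c3ccc(Br)cc23)cc1`, differs from compound 1 by less than that: hydrogen in place of hydroxy on an aromatic carbon. The change in compound 3 is a part of the larger change in compound 2, so a rise in the number is expected, but a smaller one, because the full exchange gave a 13-fold higher number from compound 1 to compound 2 (1.11 log units; beyond the scatter). Compound 3 is therefore estimated at 4500 nM, with a range from 2000 nM to 11000 nM. The expected step is a 2.8-fold higher number from compound 1 to compound 3 (0.44 log units; beyond the scatter).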

Compound 3, half-maximal inhibitory concentration: 1860 nM
Compound 3: middle estimate off by 2.4-fold (0.38 log units), on the high side, outside the stated range (below it).
By their numbers in this assay, from the lowest: compounds 1 and 3 (each within the scatter of the next); then compound 2.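

Exchanging 2,4-dihydroxyphenyl for 4-hydroxyphenyl makes no readable difference in this assay (a 1.1-fold higher number from compound 1 to compound 3 (0.06 log units; within the scatter)), so the hydroxy on this aromatic carbon, ortho to a large group, can go without a measurable loss while the other hydroxy stays. The large gap seen with 2-methylphenyl remains in full with 4-hydroxyphenyl (an 11-fold lower number from compound 2 to compound 3 (1.05 log units; beyond the scatter)), which places that gap in the part of the exchange that compound 3 does not share with compound 1. No evidence on why these numbers fall as they do accompanies this result. The compounds shown do not separate the effect of gaining the methyl from that of losing the remaining hydroxy, as neither a plain phenyl nor a 4-hydroxy-2-methylphenyl stands among them. They also leave open how a methoxy, an amine or a carboxylic acid would read in place of that remaining hydroxy.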